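Benzylsulfanyl for methylsulfanyl on the dichloro pair: compound 4

A few compounds are considered here, and "the series" means these few. Any claim that something is new, unique, unknown or untested is made for them only; others in the source may bear on it.

Measured so far in a functional assay on the whole organism (strain NMRI) with Mus musculus as the target, with a stated time of 60 min, at a dose of 20 mg/kg by the intraperitoneal route; on this read-out higher numbers stand for a stronger effect at the one dose given and lower numbers for a weaker effect:
compound 1 `CSc1nnc(Cc2ccccc2Oc2ccccc2)[nH]1` gives 147%
compound 2 `c1ccc(CSc2nnc(Cc3ccccc3Oc3ccccc3)[nH]2)cc1` gives 143%
compound 3 `CSc1nnc(Cc2ccc(Cl)cc2Oc2ccccc2Cl)[nH]1` gives 170%

Compound 3 stands highest of the three numbers in this assay; its gaps to compound 1 and to compound 2 both lie beyond the scatter.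

Compound 4 `Clc1ccc(Cc2nnc(SCc3ccccc3)[nH]2)c(Oc2ccccc2Cl)c1` is the next member and differs from compound 3 by phenyl in place of hydrogen on a saturated chain carbon bound to a sulfur. Going by the values given here, the one measured step of the same kind is a number 4 percentage points lower from compound 1 to compound 2 (within the scatter), which lies within the scatter. On that basis the step from compound 3 to compound 4 is expected to stay within the scatter as well, and a number 5 percentage points lower from compound 3 to compound 4 (within the scatter) is the estimate. For compound 4 a value of 165% is expected in this assay, within the range 145% to 185%.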

Compound 4, a percentage reported as activity, at one dose (the size of the read-out at that dose, not a potency): 129%
The estimate for compound 4 lay 36 percentage points above the measured number; the whole stated range lies above it.
By their numbers in this assay, from the lowest: compound 4; then compounds 2 and 1 (each within the scatter of the next); then compound 3.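

In this assay, benzylsulfanyl for methylsulfanyl is not a neutral change on every core, as the core of compound 3 loses activity, with a number 41 percentage points lower from compound 3 to compound 4 (beyond the scatter). The tolerance seen on the core of compound 1 therefore does not carry over, and the size of this step depends on the core that carries it: the same change on two cores in this assay, a number 4 percentage points lower (within the scatter) from compound 1 to compound 2 and a number 41 percentage points lower (beyond the scatter) from compound 3 to compound 4, 37 percentage points apart, beyond the scatter of two such steps.

Going by these compounds, the two cores differ in more than one place, and which of those differences sets the size of the step remains open. Also open, on these data alone, is how a longer chain, such as butyl, or a carboxylic acid on the sulfur would read on either core.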